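Swapping the aryl group on compound 3

A few compounds are considered here, and "the series" means these few. Any claim that something is new, unique, unknown or untested is made for them only; others in the source may bear on it.

compound 1 `Cc1ccc(-c2cc(N)n(-c3ccc(Br)cc3)n2)cc1`: 80200 nM
compound 2 `Cc1ccc(-c2nn(-c3ccc(Br)cc3)c(/N=C/N(C)C)c2C=O)cc1`: 6000 nM
compound 3 `Cc1ccc(-c2cc(/N=C/N(C)C)n(-c3cccc(Cl)c3)n2)cc1`: > 100000 nM (a limit)

Measured in a functional assay on NPC-TW01 cells (Homo sapiens) for inhibition, read by MTT assay, with a stated time of 72 h (on this read-out higher numbers stand for weaker inhibition of growth and lower numbers for stronger inhibition of growth), compound 3 reads > 100000 nM and that reading is a limit, not a number. Compound 4 `Cc1ccc(-c2cc(/N=C/N(C)C)n(-c3ccc(Br)cc3)n2)cc1` carries 4-bromophenyl in place of 3-chlorophenyl on an aromatic nitrogen. Among the compounds with values here, no measured pair isolates this change. The two compounds with 4-bromophenyl both return numbers: compound 1 (80200 nM) and compound 2 (6000 nM). On that basis a modest shift towards stronger inhibition of growth is expected in this assay, as the estimated at least 2.2-fold lower number from compound 3 to compound 4 (0.34 log units; beyond the scatter) indicates. For compound 4 the estimate is 45000 nM with an expected range of 15000 nM to 100000 nM in this read-out.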

Compound 4, concentration for 50% growth inhibition: > 100000 nM
Compound 4 ended at the assay's limit; the forecaster's own chance of this, stated with the estimate: 25%; middle value at least 2.2-fold (0.34 log units) away from the limit.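

In this assay compound 4 reads > 100000 nM, which is a limit and not a number. The aryl swap on the aromatic nitrogen cannot be read, since both of its ends are limits: the limit of > 100000 nM in this assay, at which 2 of the 4 values shown sit.
With 4-bromophenyl held fixed, hydrogen in place of formyl on an aromatic carbon gives an at least 16-fold higher number from compound 2 to compound 4 (1.22 log units; beyond the scatter), and a group of 5 heavy atoms in place of one nitrogen atom gives an at least 1.2-fold higher number from compound 1 to compound 4 (0.09 log units; that floor lies within the scatter), so only the formyl step reads as a clear change.

Going by these compounds, whether 3-chlorophenyl and 4-bromophenyl differ at this nitrogen stays open. Also open, on these data alone, is how an amine or a carboxylic acid would read in place of the formyl.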